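This account rests on a few compounds, and the source may have more. Where it says the series, first, only, none or still open, it means among the compounds named here.

Compound 1, `CC(C)c1ccc(Oc2ccc(O)c(O)c2)c(-c2ccsc2S(=O)(=O)NCCNC(=S)Nc2ccc([N+](=O)[O-])cc2)c1`: 5100 nM
Compound 2, `Cc1ccc(-c2ccsc2S(=O)(=O)NCCNC(=S)Nc2ccc([N+](=O)[O-])cc2)c(Oc2ccc(O)c(O)c2)c1`: 5100 nM
Compound 3, `O=S(=O)(NCCNC(=S)Nc1cc(C(F)(F)F)cc(C(F)(F)F)c1)c1sccc1-c1ccccc1Oc1ccc(O)c(O)c1`: 4800 nM

All three were tested in a functional assay on RS4-11 cells (Homo sapiens) for inhibition, read by CCK-8 assay, with a stated time of 48 h; on this read-out higher numbers stand for weaker inhibition and lower numbers for stronger inhibition. Compound 2 stands level with compound 1 at the digits shown, and together they hold the highest numbers of the three. The gap from compound 2 to compound 3 is within the scatter, so none of the three can be called stronger or weaker than another on these numbers.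

Compound 4, `Cc1ccc(-c2ccsc2S(=O)(=O)NCCNC(=S)Nc2cccc([N+](=O)[O-])c2)c(Oc2ccc(O)c(O)c2)c1`, has not yet been measured. It differs from compound 2 in a single place: 3-nitrophenyl in place of 4-nitrophenyl on an amide-type nitrogen. Among the measured compounds shown here, the three measured compounds differ from one another in more than one place, so no measured pair shows the effect of moving the nitro group on this phenyl ring. With nothing to point either way, the expectation is a number close to that of compound 2, with no step beyond the scatter: the estimated step is a 1.0-fold lower number from compound 2 to compound 4 (0.01 log units; within the scatter). Compound 4 is therefore expected to give 5000 nM in this assay, with a likely range from 2000 nM to 13000 nM.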

Compound 4, half-maximal inhibitory concentration: 6100 nM
The estimate for compound 4 lay 1.2-fold (0.09 log units) below the measured number; the range from low to high includes it.
By their numbers in this assay, from the lowest: compounds 3, 1, 2 and 4 (each within the scatter of the next).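

Compounds 2 and 4 are the only pair shown that differ in one place, so they give the first direct reading of this change. Putting 3-nitrophenyl in place of 4-nitrophenyl on the amide-type nitrogen gives a 1.2-fold higher number from compound 2 to compound 4 (0.08 log units; within the scatter) in this assay, so these measurements cannot separate the two nitrophenyl groups. Nothing measured here bears on why the step is this small.

Still open, from the compounds shown here alone, is whether a different group on this phenyl ring, such as an amine or a carboxylic acid in place of the nitro group, would give a step beyond the scatter. It is also open whether 2-nitrophenyl, or an unsubstituted phenyl, would read the same as the two nitrophenyl groups shown.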